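Chloro for ethoxy on the rhodanine aryl ring

This account rests on a few compounds, and the source may have more. Where it says the series, first, only, none or still open, it means among the compounds named here.

Two compounds have numbers in an assay on isolated protein for inhibition of Alpha glucosidase (Homo sapiens), read by spectrophotometry, with stated times of 15 min and 30 min; on this read-out lower numbers stand for stronger inhibition and higher numbers for weaker inhibition. Compound 1 `O=C1NC(=O)/C(=C/c2ccc(OCN3C(=O)c4ccccc4C3=O)c(Cl)c2)S1` gives 21000 nM in this assay. Compound 2 `CCOc1cc(/C=C2\SC(=S)NC2=O)ccc1OCN1C(=O)c2ccccc2C1=O` gives 7720 nM in this assay and thus stands at the lowest number of the two; compound 1 is the nearest, with a number beyond the scatter above it. Among the measured compounds shown here, compound 1 and compound 2 differ in more than one place, so their two values show only that compound 2 is the stronger of the pair without telling which change carries the difference.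

Compound 3 `O=C1NC(=S)S/C1=C\c1ccc(OCN2C(=O)c3ccccc3C2=O)c(Cl)c1` is not yet measured in this assay. It differs from compound 2 by chloro in place of ethoxy on an aromatic carbon. Compound 1 also carries a chloro and gives 21000 nM, yet it differs from compound 3 in the core as well, so no single-point comparison is at hand.

On that basis a modest weakening is expected for the step of a 1.6-fold higher number from compound 2 to compound 3 (0.19 log units; within the scatter), roughly at the edge of the scatter. Compound 3 is expected to give 12000 nM in this assay, with a range from 5000 nM to 30000 nM.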

Compound 3, half-maximal inhibitory concentration: 5440 nM
The estimate for compound 3 lay 2.2-fold (0.34 log units) above the measured number; low and high end bracket the measured number.
By their numbers in this assay, from the lowest: compounds 3 and 2 (each within the scatter of the next); then compound 1.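

In this assay, among the compounds shown here, the change of ethoxy to chloro gives the first single-place reading at this aromatic carbon, ortho to a large group: a 1.4-fold lower number from compound 2 to compound 3 (0.15 log units; within the scatter) shows no change that can be read, although 3 heavy atoms leave and 1 enters. For the compounds shown here, the exchange of one group of 8 heavy atoms, holding 2 oxygen and 1 sulfur, for another, holding 1 oxygen and 2 sulfur, gives the first single-place reading for that part of the molecule (a 3.9-fold lower number from compound 1 to compound 3 (0.59 log units; beyond the scatter)), so of the two places in which compound 1 and compound 2 differ, only this exchange has a step beyond the scatter. Nothing on hand gives a reason for either step.

Two substituents cannot define what this aromatic carbon tolerates, so a methoxy, an amine, a carboxylic acid or a longer alkoxy chain there could still move the number in either direction. It also remains open whether ethoxy and chloro stay level on the core of compound 1, as the ethoxy partner of compound 1 is missing from the compounds shown.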